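Swapping a benzyl link for a phenyl on a weak core

The source may hold more compounds than are shown below. What is called first, only, known or untested is meant among the compounds shown, and "the series" means these compounds.

Two measured compounds set the scene. Compound 1 `Cc1ccccc1Nc1nc(NCc2ccncc2)ncc1Cl` gives > 100000 nM in a functional assay on Jurkat cells (Homo sapiens) for inhibition, read by CCK-8 assay, with a stated time of 48 h (a higher number here means a weaker inhibitor of growth, a lower number a stronger inhibitor of growth), which is a limit of the assay rather than a number. Among the compounds with values here, compound 2 `COc1cccc(CNc2nc(Nc3ccc(N4CCN(C)CC4)cn3)ncc2Cl)c1` is the only compound with a numerical value in this assay, giving 73400 nM. The remaining value sits at the limit of > 100000 nM in this assay, at which 1 of the 2 values shown sits. Compound 3 `COc1cccc(Nc2nc(Nc3ccc(N4CCN(C)CC4)cn3)ncc2Cl)c1` has not yet been measured. It differs from compound 2 in one place: 3-methoxyphenyl in place of 3-methoxybenzyl on a nitrogen on an aromatic ring. Within the data shown here, no measured pair shows this change on its own, and compound 1 differs from compound 3 in more than one place, so its limit offers no guide to the size of the step. The expected step of a 1.2-fold lower number from compound 2 to compound 3 (0.09 log units; within the scatter) is estimated to stay within the usual scatter, in no clear direction. Compound 3 is expected to give about 60000 nM in this assay, within a range from 15000 nM to 200000 nM.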

Compound 3, concentration for 50% growth inhibition: 15800 nM
Compound 3: the middle estimate sits 3.8-fold (0.58 log units) above what was measured; the range from low to high includes it.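

In this assay, putting 3-methoxyphenyl in place of 3-methoxybenzyl on this nitrogen gives a 4.6-fold lower number from compound 2 to compound 3 (0.67 log units; beyond the scatter). This is the first pair shown that differs in one place, and it shows that this position responds to the change: the direct phenyl attachment gives the stronger inhibitor of growth of the two, by more than the usual scatter. Nothing measured here explains why the shorter attachment does better.

The compounds shown leave open whether a longer chain, such as 2-phenylethyl, on the same nitrogen would weaken growth inhibition further. They also leave open how much the methoxy group itself contributes, and whether an amine or a carboxylic acid in its place on the phenyl ring would keep the stronger value of compound 3.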